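A few compounds are considered here, and "the series" means these few. Any claim that something is new, unique, unknown or untested is made for them only; others in the source may bear on it.

Compound 1 `Cc1cc(NC(=O)Cn2nnc(-c3ccccc3)n2)n(C2CCC(F)(F)CC2)n1` is the anchor of this small set: in an assay on HEK293 cells for activation of Kir3.1/Kir3.2 (Homo sapiens), read by thallium flux (on this read-out higher numbers stand for an effect only at larger amounts of compound and lower numbers for an effect already at smaller amounts), compound 1 gives 84 nM. Compound 2 `CCC(C)n1nc(C)cc1NC(=O)Cn1nnc(-c2ccccc2)n1` differs from it only by a sec-butyl group in place of the 4,4-difluorocyclohexyl group on the aromatic nitrogen, and that single exchange brings an at least 59-fold higher number from compound 1 to compound 2 (1.77 log units; beyond the scatter). For compound 2 the value is a limit of the assay rather than a number, > 5000 nM, which is the limit of > 5000 nM in this assay, at which 1 of the 2 values shown sits. Compound 3 `Cc1cc(NC(=O)Cn2nnc(-c3ccccc3)n2)n(C2CC2)n1` has not been measured; against compound 2 it shows (cyclopropyl in place of sec-butyl on an aromatic nitrogen). Going by the values given here, only one measured step bears on this change, an at least 59-fold higher number from compound 1 to compound 2 (1.77 log units; beyond the scatter), and it shows that trading the ring-bearing group for a group without a ring at this position loses activity heavily. Cyclopropyl restores a ring, though a much smaller one than in compound 1, so compound 3 is expected to stay weak in this assay, with an estimated step of an at least 1.6-fold lower number from compound 2 to compound 3 (0.22 log units; that floor lies within the scatter). The estimate for compound 3 in this assay is 3000 nM, within a range from 500 nM to 20000 nM, and a limit may well be reported again.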

Compound 3, half-maximal effective concentration: > 5000 nM
Compound 3 was reported as a limit (the forecaster's own chance of this, stated with the estimate: 45%); middle value at least 1.6-fold (0.22 log units) from the limit.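

In this assay, cyclopropyl in place of 4,4-difluorocyclohexyl brings an at least 59-fold higher number from compound 1 to compound 3 (1.77 log units; beyond the scatter), so the loss at this position is not confined to the ring-free sec-butyl group: a ring on the aromatic nitrogen is not enough on its own to keep the activity. Of the three groups shown at this place, only the 4,4-difluorocyclohexyl group of compound 1 gives a value that is a number rather than a limit. The step between compound 2 and compound 3 cannot be read, so the exchange of sec-butyl for cyclopropyl cannot be ranked, and the limit hides any difference between them: the limit of > 5000 nM in this assay, at which 2 of the 3 values shown sit.

From the compounds shown here alone, what stays open is whether the size of the ring, the fluorine atoms, or both account for the activity of compound 1; a plain cyclohexyl or a cyclopentyl group on this nitrogen would speak to that question. It also remains unclear how steeply activity falls between the large ring of compound 1 and the small groups of compound 2 and compound 3, since both of these lie beyond what the read-out can resolve.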